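The source may report more compounds than this note shows. Statements on the series, on what has been measured and on what is new or still open speak of the compounds shown alone.

Measured compounds:
Compound 1 `CC1COC2(C=CC(=O)C=C2)N(C(C)C)C1=O` in an assay on isolated protein for inhibition of N-lysine methyltransferase SMYD2 (Homo sapiens), read by filter binding, with a stated time of 1 h (on this read-out higher numbers stand for weaker inhibition and lower numbers for stronger inhibition), gives > 20000 nM, a limit of the assay.
Compound 2 `C=CCC1COC2(C=CC(=O)C=C2)N(C(C)C)C1=O` gives > 20000 nM, likewise a limit.
Compound 3 `CC(C)N1C(=O)C(Cc2ccc(Cl)cc2)COC12C=CC(=O)C=C2` gives > 20000 nM, again a limit.

All three values sit at the same limit (the limit of > 20000 nM in this assay, at which 3 of the 3 values shown sit), so compound 3 stands nowhere distinguishable from the other two. The steps measured so far, a step that the two limits leave unreadable from compound 1 to compound 2, a step that the two limits leave unreadable from compound 1 to compound 3 and a step that the two limits leave unreadable from compound 2 to compound 3, are unreadable in size for that reason. Compound 4 `CC(C)N1C(=O)C(Cc2ccc(F)cc2)COC12C=CC(=O)C=C2` differs from compound 3 by fluoro in place of chloro on an aromatic carbon. Going by the values given here, no measured step bears readably on this change, so compound 4 is expected to stay at a limit as well, and the step from compound 3 to compound 4 is estimated as a step that the limit leaves unreadable from compound 3 to compound 4. The estimate for compound 4 is 30000 nM, between 8000 nM and 100000 nM.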

Compound 4, half-maximal inhibitory concentration: > 20000 nM
Compound 4: no number, only a limit (the forecaster's own chance of this, stated with the estimate: 85%); the middle value is on the limit's open side.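

Compound 4, like compound 1, compound 2 and compound 3, gives only a limit and not a number, so no step among these compounds can be read: the limit of > 20000 nM in this assay, at which 4 of the 4 values shown sit.

The compounds shown leave open which change to the shared core, if any, would give a readable value in this assay.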